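Shared-core series: expected cytotoxicity of compound 4 from compound 2

This account rests on a few compounds, and the source may have more. Where it says the series, first, only, none or still open, it means among the compounds named here.

Compound 1 `CC(C)CN1C(=O)/C(=C/c2ccc(Cl)cc2)S/C1=N\c1ccccc1` carries the shared core and in an ADME assay on HepG2 cells (Homo sapiens) for cytotoxicity, read by MTT assay, with a stated time of 48 h (on this read-out higher numbers stand for weaker inhibition and lower numbers for stronger inhibition), compound 1 gives "not determined" (no result reported). Compound 3 `Cc1ccc(/C=C2\S/C(=N\c3ccccc3)N(CC(C)C)C2=O)cc1` carries the shared core too and in this assay compound 3 gives "not determined" (no result reported). Compound 2 `CC(C)CN1C(=O)/C(=C/c2ccc(N(C)C)cc2)S/C1=N\c1ccccc1` in this assay gives > 100000 nM, which is a limit of the measurement and not a number. Compound 2 therefore sits at the limit of > 100000 nM in this assay, at which 1 of the 3 values shown sits. The two other entries stand without any number. Compound 4 `CC(C)CN1C(=O)/C(=C/c2ccccn2)S/C1=N\c1ccccc1` is not yet measured and differs from compound 2 by pyridin-2-yl in place of 4-(dimethylamino)phenyl on a double-bonded chain carbon bound to a double-bonded ring carbon. Within the data shown here, no step between measured compounds exists in the set, so no change beyond the usual scatter is expected in this assay; the estimated step is a number no higher from compound 2 to compound 4 (the limit leaves the size open). For compound 4 the expected value is 100000 nM, with a range from 40000 nM to 200000 nM, most likely again reported only as a limit.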

Compound 4, half-maximal inhibitory concentration: > 100000 nM
Compound 4: no number, only a limit; the forecaster's own chance of this, stated with the estimate: 70%; the middle value sits exactly at the limit.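

Among these compounds, compound 2 and compound 4 both stand only as limits in this assay, so no step between them can be read. The compounds shown leave open what cytotoxic concentration, if any, either compound has in this assay.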